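The compounds below may be only part of what the source reports. "The series", "measured", "known", "first", "only" and "open" are said of these compounds alone.

Two members of the series have numbers in a functional assay on the whole organism (blood) with Rattus norvegicus as the target, with stated times of 24 h and 1 h, at a dose of 5 mg/kg by the intraperitoneal route; on this read-out higher numbers stand for a stronger effect at the one dose given and lower numbers for a weaker effect. Compound 1 `O=C(NC1CCCCC1)NS(=O)(=O)N1CCC(CCNC(=O)c2csnn2)CC1` gives 19%, the lower of the two. Compound 2 `O=C(NC[C@@H]1C[C@@H]2C=C[C@@H]1C2)NS(=O)(=O)N1CCC(CCNC(=O)c2cccc3cccnc23)CC1` gives 34%, a gap to compound 1 that lies beyond the usual scatter. Compound 3 `O=C(NC1CCCCC1)NS(=O)(=O)N1CCC(CCNC(=O)c2cc(Cl)cc3cccnc23)CC1` awaits measurement. It differs from compound 1 in one place: 6-chloroquinolin-8-yl in place of 1,2,3-thiadiazol-4-yl on a carbonyl carbon. Among the compounds with values here, no measured pair differs only in this place, and compound 2 differs from compound 3 in more than one place, so its value is only a loose pointer. A modest step upward is expected, a number 11 percentage points higher from compound 1 to compound 3 (beyond the scatter), though it may fall within the scatter. For compound 3 the expected value is 30%, with a range from 15% to 48%.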

Compound 3, a percentage reported as activity, at one dose (the size of the read-out at that dose, not a potency): 52%
Compound 3: middle estimate off by 22 percentage points, on the low side; the whole stated range lies below it.
By their numbers in this assay, from the lowest: compound 1; then compound 2; then compound 3.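

In this assay, the group on the carbonyl carbon of the amide-type nitrogen proves a sensitive place: 6-chloroquinolin-8-yl in place of 1,2,3-thiadiazol-4-yl gives a number 33 percentage points higher from compound 1 to compound 3 (beyond the scatter) on the core of compound 1. Within the data shown here, this is the first single-place change, and it shows that this position alone can move the read-out substantially. Nothing measured here bears on the origin of this step.

As far as these compounds go, the step combines the change of ring system with the chlorine, so their separate shares remain open. A simple phenyl group at this place would help show how much the second ring and the chlorine each contribute.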